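Compound 3: chloro for hydroxy, expected inhibition read-out

The source may report more compounds than this note shows. Statements on the series, on what has been measured and on what is new or still open speak of the compounds shown alone.

Going by the values given here, compound 2 `COc1ccc(/C=N/N(C)C(=O)c2ccc(O)cc2)cc1OC` stands within the scatter of its one neighbour in a functional assay on the whole organism (lung, strain A/J) for inhibition, with Mus musculus as the target, with stated times of 1 h and 18 h, at a dose of 100 umol/kg by the oral route; on this read-out higher numbers stand for more inhibition at the one dose given (going by the name of the read-out) and lower numbers for less inhibition: compound 2 gives 60%, and compound 1 `COc1ccc(C(=O)N(C)/N=C/c2ccc(OC)c(OC)c2)cc1` gives 68%. Among the compounds with values here, the one measured step, a number 8 percentage points lower from compound 1 to compound 2 (within the scatter), is within the scatter. Compound 3 `COc1ccc(/C=N/N(C)C(=O)c2ccc(Cl)cc2)cc1OC` differs from compound 2 by chloro in place of hydroxy on an aromatic carbon. Within the data shown here, no measured step covers a chloro entering here, so no direction beyond the scatter is expected; the expected step is a number 2 percentage points higher from compound 2 to compound 3 (within the scatter). Compound 3 is estimated at 62% in this assay, between 40% and 80%.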

Compound 3, a percentage reported as inhibition, in the whole organism at one dose (the size of the read-out at that dose, not a potency): 54%
Compound 3: middle estimate off by 8 percentage points, on the high side; measured number inside the range.
By their numbers in this assay, from the lowest: compounds 3, 2 and 1 (each within the scatter of the next, the first and the last beyond it).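

In this assay, the change from 4-hydroxyphenyl to 4-chlorophenyl gives a number 6 percentage points lower from compound 2 to compound 3 (within the scatter), so chloro and hydroxy cannot be told apart at this position, para to a large group, although chloro counts no hydrogen-bond donor. Chloro in place of methoxy on the same carbon gives a number 14 percentage points lower from compound 1 to compound 3 (beyond the scatter), the first step in the series to lie beyond the scatter. Nothing available bears on the reason for either step. Going by these compounds, whether an amine or a carboxylic acid on this carbon would separate from hydroxy, chloro or methoxy stays open. The single-dose read-out also leaves potency open.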